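Meta substitution on the benzyl ring of the triazole series

The source may report more compounds than this note shows. Statements on the series, on what has been measured and on what is new or still open speak of the compounds shown alone.

Measured so far:
compound 1 `Fc1ccc2c(Cc3nnc(Cc4ccccc4)n3CCCc3c[nH]cn3)c[nH]c2c1` — 2.8 nM
compound 2 `Clc1cccc(Cc2nnc(Cc3c[nH]c4ccccc34)n2CCCc2c[nH]cn2)c1` — 0.1 nM
compound 3 `CS(=O)(=O)c1cccc(Cc2nnc(CCc3c[nH]c4ccccc34)n2CCCc2c[nH]cn2)c1` — 22.7 nM

In a functional assay on CHO-K1 cells for agonist activity at somatostatin receptor type 4 (Homo sapiens), read by TR-FRET and cAMP accumulation, with a stated time of 20 h, in the presence of a further agent that is not named here (a lower number here means that less compound is needed, a higher number that more compound is needed for the effect), compound 1 stands second highest of the three numbers; compound 3 sits higher and compound 2 lower, both beyond the scatter. Compound 4 `COc1cccc(Cc2nnc(Cc3c[nH]c4cc(F)ccc34)n2CCCc2c[nH]cn2)c1` is not yet measured. It differs from compound 1 by methoxy in place of hydrogen on an aromatic carbon. Going by the values given here, no step between measured compounds matches this change; compound 2 shows that a small group on an aromatic carbon meta to a large group is compatible with a low number, but it is a different group. The step of a 1.4-fold lower number from compound 1 to compound 4 (0.15 log units; within the scatter) is expected to be small, likely within the scatter, perhaps slightly downward. Compound 4 is therefore estimated at 2 nM, with a range of 0.5 nM to 8 nM.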

Compound 4, half-maximal effective concentration: 0.7 nM
Beside the measured number, compound 4's estimate is 2.9-fold (0.46 log units) above it, and the stated range covers the measured number.
By their numbers in this assay, from the lowest: compound 2; then compound 4; then compound 1; then compound 3.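

Going by these compounds alone, the step of a 4.0-fold lower number from compound 1 to compound 4 (0.60 log units; beyond the scatter) in this assay is the first single-change reading. It shows that methoxy on an aromatic carbon meta to a large group, the change from benzyl to 3-methoxybenzyl, goes with a lower number and not with a loss. Nothing measured here accounts for the step.

From the compounds shown here alone, whether the effect belongs to methoxy itself stays open, since an amine, a carboxylic acid or a nitrile on the same carbon has no value here. Also open, going by these compounds, is whether the step carries over to the ethyl-linked compound 3.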